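Swapping a Carboxyhexyl Chain for Pyridin-2-yl

A few compounds are considered here, and "the series" means these few. Any claim that something is new, unique, unknown or untested is made for them only; others in the source may bear on it.

Measured so far:
Compound 1 `COC(=O)C1C(=O)C(C(=O)OC)[C@H](c2ccccn2)N(CCCCCCCC(=O)O)[C@@H]1c1ccccn1`, in an ADME assay on J774.1 cells (Mus musculus) for cytotoxicity, with a stated time of 48 h (on this read-out lower numbers stand for an effect already at smaller amounts and higher numbers for an effect only at larger amounts of compound), compound 1 gives 33.8 uM.
Compound 2 `COC(=O)c1c(-c2ccccn2)n(Cc2ccc(Cl)cc2)c(-c2ccccn2)cc1=O`, for which compound 2 shows > 100 uM, a limit of the assay rather than a number.

Within the data shown here, compound 1 holds the only real number in this set. The other entry, for compound 2, is only a limit, as recorded in the limit of > 100 uM in this assay, at which 1 of the 2 values shown sits. Compound 2 shares none of the saturated core of compound 1, so the two values say nothing about any single structural step.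

The compound not yet measured is compound 3 `COC(=O)C1C(=O)C(C(=O)OC)[C@H](c2ccccn2)N(Cc2ccccn2)[C@@H]1c1ccccn1`. Its change from compound 1 is pyridin-2-yl in place of 6-carboxyhexyl on a saturated chain carbon bound to an amine nitrogen in a ring. Among the measured compounds shown here, since no measured pair in the data differs in one place, there is no directly comparable step to lean on. The expectation here is a step from compound 1 to compound 3 of about a 1.4-fold lower number from compound 1 to compound 3 (0.13 log units; within the scatter), that is, no change beyond the usual scatter, possibly a slightly lower value. On that basis compound 3 is estimated at 25 uM, with a plausible range from 8 uM to 80 uM.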

Compound 3, concentration for half-maximal effect: 29.9 uM
The estimate for compound 3 lay 1.2-fold (0.08 log units) below the measured number; the measured number falls inside the stated range.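

In this assay, the step from the 6-carboxyhexyl chain to pyridin-2-yl, on a saturated chain carbon bound to an amine nitrogen in a ring, gives a 1.1-fold lower number from compound 1 to compound 3 (0.05 log units; within the scatter), so the two compounds cannot be told apart. Among these compounds, this is the first comparison in the set between compounds that differ in one place, and it shows that a very different group can stand at this place without a measurable shift: an open chain with a hydrogen-bond donor gives way to a six-membered aromatic ring with none, and the value in this assay stays within the usual scatter. Nothing measured here explains why the two values agree.

This is still a single pair on a single core, so it cannot show whether the same holds for other groups at this place, such as a chain ending in an amine, a shorter chain or a plain benzyl group. It also leaves open whether any group at this place would move the value in this assay beyond the scatter, in either direction.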